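Cyclopropyl Amide Swap on a Weak HepG2 Inhibitor

The source may report more compounds than this note shows. Statements on the series, on what has been measured and on what is new or still open speak of the compounds shown alone.

Of the compounds shown here, two have been measured in a functional assay on HepG2 cells (Homo sapiens) for antiproliferative activity, read by CCK-8 assay, with a stated time of 48 h; a higher number here means a weaker inhibitor, a lower number a stronger inhibitor. Compound 1 `O=C(NC1CC1)c1cc(Oc2ccc(/C=C/c3ccccn3)cc2)ccn1` carries a cyclopropyl group on its amide nitrogen, and in this assay compound 1 gives 31000 nM. Compound 2 `O=C(Nc1ccc(Cl)cc1)c1cc(Oc2ccc(/C=C/c3ccncc3)cc2)ccn1` carries a 4-chlorophenyl group on the same kind of nitrogen and differs from compound 1 in a second place as well; in this assay compound 2 gives 56200 nM. Compound 2 holds the higher of the two numbers, but the gap to compound 1 lies within the usual scatter, so the two values cannot be told apart with confidence.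

Compound 3 `O=C(NC1CC1)c1cc(Oc2ccc(/C=C/c3ccncc3)cc2)ccn1` is the untested analogue. The change from compound 2 is cyclopropyl in place of 4-chlorophenyl on an amide-type nitrogen. Among the measured compounds shown here, the only measured compound sharing this cyclopropyl amide, compound 1, gives a number within the scatter of compound 2, so no step beyond the scatter is expected in either direction. The estimated step of a 1.5-fold lower number from compound 2 to compound 3 (0.17 log units; within the scatter) reflects this. Compound 3 is therefore expected to give about 38000 nM in this assay, with a plausible range from 12000 nM to 120000 nM.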

Compound 3, half-maximal inhibitory concentration: 77500 nM
The estimate for compound 3 lay 2.0-fold (0.31 log units) below the measured number; measured number inside the range.
By their numbers in this assay, from the lowest: compounds 1, 2 and 3 (each within the scatter of the next, the first and the last beyond it).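

In this assay, putting cyclopropyl in place of 4-chlorophenyl on the amide-type nitrogen gives a 1.4-fold higher number from compound 2 to compound 3 (0.14 log units; within the scatter) and so does not separate the two groups at this position, even though the group that enters has 3 heavy atoms and the one that leaves has 7. Among the compounds shown here, compound 3 also makes the first clean single-place comparison for the other end of the molecule: with the cyclopropyl amide held constant, pyridin-4-yl in place of pyridin-2-yl on a double-bonded chain carbon gives a 2.5-fold higher number from compound 1 to compound 3 (0.40 log units; beyond the scatter) as a modest step and the only one here beyond the scatter. Nothing measured here explains either result.

For the compounds shown here, only two groups on the amide-type nitrogen can be compared here, so it remains open whether a longer chain, a benzyl group or a group carrying an amine would shift the number beyond the scatter. On these data alone, it is also open whether pyridin-3-yl on the double-bonded chain would follow either pyridine compared here, and whether the pyridine step would hold with 4-chlorophenyl on the amide.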